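Side-chain amine variation on the diaryl urea core

A few compounds are considered here, and "the series" means these few. Any claim that something is new, unique, unknown or untested is made for them only; others in the source may bear on it.

Measured so far:
compound 1 `CCCCCN(CCCCC)C(=O)N1CCN(C(=O)N(c2ccccc2)c2ccccc2)[C@H](C(=O)NCCN(C(C)C)C(C)C)C1`: 217 nM
compound 2 `CCCCCN(CCCCC)C(=O)N1CCN(C(=O)N(c2ccccc2)c2ccccc2)[C@H](C(=O)N(C)CCN(C)C)C1`: 930 nM

In an assay on CHO cells for binding affinity to Substance-P receptor (Homo sapiens) (a lower number here means a stronger inhibitor, a higher number a weaker inhibitor), compound 1 gives 217 nM, the lowest of the two numbers; the step of a 4.3-fold higher number from compound 1 to compound 2 (0.63 log units; beyond the scatter) separates it from compound 2, which gives 930 nM in this assay.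

Compound 3 `CCCCCN(CCCCC)C(=O)N1CCN(C(=O)N(c2ccccc2)c2ccccc2)[C@H](C(=O)NCCNCc2ccccc2OC)C1` is the third member. Its difference from compound 1 is (2-methoxybenzyl)amino in place of diisopropylamino on a saturated chain carbon, two bonds along the chain from an amide-type nitrogen, on a saturated chain carbon two bonds along the chain from an amide-type nitrogen. Within the data shown here, the only measured step, a 4.3-fold higher number from compound 1 to compound 2 (0.63 log units; beyond the scatter), alters the same side-chain amine but in a different way, so it shows that this position tolerates change with a modest shift and gives no direct guide for the entering group. A step of a 1.4-fold higher number from compound 1 to compound 3 (0.14 log units; within the scatter) of about the same order or smaller is expected for compound 3, in either direction. Compound 3 is thus estimated at 300 nM, within 80 nM to 1200 nM.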

Compound 3, half-maximal inhibitory concentration: 9 nM
For compound 3 the middle estimate is 33-fold (1.52 log units) above the measured one; the whole stated range lies above it.
By their numbers in this assay, from the lowest: compound 3; then compound 1; then compound 2.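

In this assay, 2-((2-methoxybenzyl)amino)ethyl in place of 2-(diisopropylamino)ethyl gives a 24-fold lower number from compound 1 to compound 3 (1.38 log units; beyond the scatter), so the amine on this chain can move the number much further than a 4.3-fold higher number from compound 1 to compound 2 (0.63 log units; beyond the scatter) suggested. The entering group differs from diisopropylamino in several ways at once, including a six-membered aromatic ring of carbon only, an oxygen and a hydrogen-bond donor, and this single step cannot separate their contributions. No supporting measurement accounts for the large drop.

On these data alone, whether the methoxy group contributes remains open: a plain benzylamino group or a (2-chlorobenzyl)amino group in the same place would test this. Also open, as far as these compounds go, is the role of the hydrogen on the entering amine, which a (2-methoxybenzyl)(methyl)amino group would address.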